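Swapping Methoxy for Chloro in a Sulfonamide-Amide Series

The source may hold more compounds than are shown below. What is called first, only, known or untested is meant among the compounds shown, and "the series" means these compounds.

Measured compounds:
- compound 1 `COc1ccccc1C(=O)NCc1ccc(CNS(=O)(=O)c2ccccc2)cc1`: "not active" (no number reported) in a functional assay on the whole organism for inhibition, with Mus musculus as the target, with stated times of 30 min and 2 h, at a dose of 10 mg/kg by the intraperitoneal route; on this read-out higher numbers stand for more inhibition at the one dose given (going by the name of the read-out) and lower numbers for less inhibition
- compound 2 `Cc1ccc(S(=O)(=O)NCc2ccc(CNC(=O)c3ccc(Cl)cc3)cc2)cc1`: 50%
- compound 3 `Cc1ccc(S(=O)(=O)NCc2ccc(CNC(=O)c3cccc(Cl)c3)cc2)cc1`: 57%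

Compound 1 stands without a single number in this assay; it was reported as inactive. Compound 4 `O=C(NCc1ccc(CNS(=O)(=O)c2ccccc2)cc1)c1ccccc1Cl` differs from compound 1 by chloro in place of methoxy on an aromatic carbon. Among the compounds with values here, no measured step matches this change directly. Within the data shown here, the only measured step, a number 7 percentage points higher from compound 2 to compound 3 (within the scatter), shifts chloro on the same ring but on a core carrying a different sulfonyl group, so it bears only loosely here. Compounds 2 and 3, both bearing chloro, do give clear readings, whereas compound 1 with methoxy gives none. A rise from compound 1 is therefore plausible, but its size is uncertain. Compound 4 is expected to give about 35% in this assay, within 5% to 65%.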

Compound 4, a percentage reported as inhibition, in the whole organism at one dose (the size of the read-out at that dose, not a potency): "not active" (no number reported)
Compound 4: no number reported; no gap can be computed for the estimate.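

In this assay compound 1 gives "not active" (no number reported) and compound 4 gives "not active" (no number reported), so no step can be read between them. The compounds shown leave open whether 2-methoxyphenyl to 2-chlorophenyl changes inhibition at all. No measurement here bears on this result.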